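Aryl variation on the shared core: compound 3 to compound 4

The source may report more compounds than this note shows. Statements on the series, on what has been measured and on what is new or still open speak of the compounds shown alone.

Three analogues share one core and differ only in the aryl group on the saturated ring carbon. Compound 1 `C=CC(=O)N1C(=O)CC(c2ccc([N+](=O)[O-])cc2)Sc2ccccc21` gives 91500 nM in a functional assay on MOLT-4 cells (Homo sapiens) for cytotoxicity, read by CCK-8 assay, with a stated time of 24 h; a lower number here means a stronger inhibitor, a higher number a weaker inhibitor. Compound 2 `C=CC(=O)N1C(=O)CC(c2ccc(C)cc2)Sc2ccccc21` gives 87600 nM in this assay, and the step of a 1.0-fold lower number from compound 1 to compound 2 (0.02 log units; within the scatter) shows that exchanging the nitro for a methyl on the aromatic carbon changes nothing beyond the scatter. Compound 3 `C=CC(=O)N1C(=O)CC(c2cccc(Cl)c2)Sc2ccccc21` gives 77500 nM in this assay; the step of a 1.1-fold lower number from compound 2 to compound 3 (0.05 log units; within the scatter) is likewise within the scatter. Compound 3 therefore carries the lowest of the three numbers, but its gaps to compound 2 and compound 1 are both within the scatter, so no ranking among the three can be drawn.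

Compound 4 `C=CC(=O)N1C(=O)CC(c2ccc(OC)cc2)Sc2ccccc21` continues the same variation: 4-methoxyphenyl in place of 3-chlorophenyl on a saturated ring carbon. Within the data shown here, two measured steps bear on it, the aryl exchange on the same saturated ring carbon from compound 2 to compound 3 and the change of substituent on the aromatic carbon from compound 1 to compound 2; both were within the scatter. For compound 4, accordingly, no step beyond the scatter in this assay is expected in either direction. The expected step is a 1.1-fold higher number from compound 3 to compound 4 (0.02 log units; within the scatter), within the scatter. Compound 4 is estimated at 82000 nM, with a range from 40000 nM to 170000 nM.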

Compound 4, half-maximal inhibitory concentration: 83200 nM
Beside the measured number, compound 4's estimate is 1.0-fold (0.01 log units) below it; low and high end bracket the measured number.
By their numbers in this assay, from the lowest: compounds 3, 4, 2 and 1 (each within the scatter of the next).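

In this assay, the exchange of 3-chlorophenyl for 4-methoxyphenyl on the saturated ring carbon next to the ring sulfur brings in a group with 1 hydrogen-bond acceptor where the leaving group has 0, and the result is a 1.1-fold higher number from compound 3 to compound 4 (0.03 log units; within the scatter). Methoxy in place of methyl on an aromatic carbon gives a 1.1-fold lower number from compound 2 to compound 4 (0.02 log units; within the scatter), and methoxy in place of nitro gives a 1.1-fold lower number from compound 1 to compound 4 (0.04 log units; within the scatter), so nitro, methyl and methoxy on the phenyl ring, together with the 3-chlorophenyl variant, have so far produced no step beyond the scatter at this position. No measurement at hand bears on why the four numbers lie so close together.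

As far as these compounds go, whether any group at this position can move the number beyond the scatter stays open, for example an amine or a carboxylic acid on the phenyl ring, or a longer chain in place of the aryl group. All four compounds carry the vinylcarbonyl group on the ring nitrogen, so the contribution of that group to these numbers also remains unresolved.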